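The compounds below may be only part of what the source reports. "The series", "measured", "known", "first", "only" and "open" are said of these compounds alone.

Measured so far in a physicochemical assay for solubility, in phosphate buffer, measured as kinetic solubility, at pH 7.4; on this read-out higher numbers stand for higher solubility and lower numbers for lower solubility:
Compound 1 `Cc1cccc(-c2nc(CN3CCC(C(=O)NCCCN4C[C@H](C)C[C@H](C)C4)CC3)c(C)o2)c1`: > 69 ug/mL
Compound 2 `COc1cccc(F)c1-c1nc(CN2CCC(C(=O)NCCCN3C[C@H](C)C[C@H](C)C3)CC2)c(C)o1`: > 74 ug/mL

Both entries are limits of the assay and not numbers. Compound 2 stands at > 74 ug/mL, which is a limit. Compound 1 gives > 69 ug/mL, which is also a limit.

The next compound is compound 3 `COc1cccc(OC)c1-c1nc(CN2CCC(C(=O)NCCCN3C[C@H](C)C[C@H](C)C3)CC2)c(C)o1`, which carries methoxy in place of fluoro on an aromatic carbon, ortho to a large group: methoxy in place of fluoro on an aromatic carbon. The same difference, cut one bond further out, reads 2-fluoro-6-methoxyphenyl to 2,6-dimethoxyphenyl.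

Among the measured compounds shown here, one measured step bears on this change: a step that the two limits leave unreadable from compound 1 to compound 2. That step has no readable size, so it offers no ground for a shift in either direction. No change beyond the scatter is therefore expected in this assay, and compound 3 is expected to return a limit as well. The expected step is a step that the limit leaves unreadable from compound 2 to compound 3. For compound 3 the estimate is 76 ug/mL, with an expected range from 50 ug/mL to 120 ug/mL.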

Compound 3, solubility: > 76 ug/mL
Compound 3 ended at the assay's limit (the forecaster's own chance of this, stated with the estimate: 85%); the middle value lies on the limit itself.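

In this assay compound 3 gives > 76 ug/mL, which is a limit of the assay. Among the compounds shown here, compound 1 and compound 2 also stand at limits, so no step among compound 1, compound 2 and compound 3 can be read. The compounds shown leave open whether any of these changes on the aromatic ring makes a difference in this assay.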